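From 4-fluorobenzyl to propyl on a shared core

This account rests on a few compounds, and the source may have more. Where it says the series, first, only, none or still open, it means among the compounds named here.

In a functional assay on RAW264.7 cells (Mus musculus) for inhibition, read by Griess assay, with stated times of 1 h and 24 h (on this read-out lower numbers stand for stronger inhibition and higher numbers for weaker inhibition), compound 1 `O=C1CC(c2ccccc2OCc2ccc(F)cc2)Oc2ccccc21` gives 28200 nM. Within the data shown here, its only measured neighbour, compound 2 `CC(C)CCOc1ccccc1C1CC(=O)c2ccccc2O1`, gives 39200 nM. These two values lie within the scatter of each other, so compound 1 holds no clear rank of its own.

Compound 3 `CCCOc1ccccc1C1CC(=O)c2ccccc2O1` has not yet been measured. It keeps the core of compound 1 and differs in one group: ethyl in place of 4-fluorophenyl on a saturated chain carbon bound to an oxygen on an aromatic ring. The change is ethyl in place of 4-fluorophenyl on a saturated chain carbon bound to an oxygen on an aromatic ring, which can also be read as 4-fluorobenzyl to propyl.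

Among the measured compounds shown here, one measured step bears on this, the swap of 4-fluorophenyl for isobutyl at that same place: a 1.4-fold higher number from compound 1 to compound 2 (0.14 log units; within the scatter). There, an open chain took over from the ring and the number stayed within the scatter, although a single pair is thin evidence. No shift beyond the scatter is therefore expected, and the estimated step is a 1.3-fold higher number from compound 1 to compound 3 (0.11 log units; within the scatter). In this assay, the estimate for compound 3 is 36000 nM, with an expected range from 16000 nM to 80000 nM.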

Compound 3, half-maximal inhibitory concentration: 46000 nM
The estimate for compound 3 lay 1.3-fold (0.11 log units) below the measured number; measured number inside the range.
By their numbers in this assay, from the lowest: compounds 1, 2 and 3 (each within the scatter of the next).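

Removing the 4-fluorophenyl ring and leaving only ethyl in its place is a larger change than the swap to isobutyl, yet this assay records a 1.6-fold higher number from compound 1 to compound 3 (0.21 log units; within the scatter), so even this cut does not separate the two compounds. Within the open chains, methyl in place of isopropyl on a saturated chain carbon, two bonds along the chain from an oxygen on an aromatic ring, gives a 1.2-fold higher number from compound 2 to compound 3 (0.07 log units; within the scatter), so this change in the chain does not separate them either. Across these three compounds, then, neither the aromatic ring on the chain nor the branched end of the chain is needed to keep the number within the scatter, and no order can be read among the three groups.

The compounds shown leave open whether a longer chain, or an amine or a carboxylic acid carried on this chain, would move the number beyond the scatter, a result that would show this position can affect the read-out at all. No measurement is available to explain why these numbers lie so close together.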